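Methylsulfonyl for isopropyl on the pendant phenyl

A few compounds are considered here, and "the series" means these few. Any claim that something is new, unique, unknown or untested is made for them only; others in the source may bear on it.

Measured so far:
Compound 1, `CCCS(=O)(=O)Nc1ccc(F)c(C(=O)c2n[nH]c3ncc(-c4ccccc4OC)cc23)c1F`: 1.9%
Compound 2, `CCCS(=O)(=O)Nc1ccc(F)c(C(=O)c2n[nH]c3ncc(-c4ccc(C(C)C)cc4)cc23)c1F`: 17%

In an assay for binding affinity to dual specificity mitogen-activated protein kinase kinase 4 (Homo sapiens), read by KINOMEscan, tested at 100 nM (a lower number here means a stronger effect, a higher number a weaker effect of the compound at the concentration tested), compound 2 stands highest of the two numbers, with compound 1 as the nearest value. For the measured compounds named here, the one measured step, a number 15.1 percentage points higher from compound 1 to compound 2 (beyond the scatter), concerns the same pendant phenyl but a different substituent pattern. Compound 3, `CCCS(=O)(=O)Nc1ccc(F)c(C(=O)c2n[nH]c3ncc(-c4ccc(S(C)(=O)=O)cc4)cc23)c1F`, differs from compound 2 as follows: methylsulfonyl in place of isopropyl on an aromatic carbon. Going by the values given here, no measured step involves a methylsulfonyl group, so the expectation rests only on compound 2 itself. The step of a number 5 percentage points lower from compound 2 to compound 3 (within the scatter) is expected to fall within the scatter, with a wide range. Compound 3 is estimated at 12%, between 2% and 40%.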

Compound 3, a percentage reported as activity, at one concentration (the size of the read-out at that concentration, not a potency): 1.5%
Compound 3: middle estimate off by 10.5 percentage points, on the high side; measured number below the stated range.
By their numbers in this assay, from the lowest: compounds 3 and 1 (each within the scatter of the next); then compound 2.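

Replacing isopropyl with methylsulfonyl on the same aromatic carbon gives a number 15.5 percentage points lower from compound 2 to compound 3 (beyond the scatter) in this assay, so the higher number of compound 2 is not shared by every group at that carbon. The 4-(methylsulfonyl)phenyl and 2-methoxyphenyl groups cannot be told apart here, with a number 0.4 percentage points lower from compound 1 to compound 3 (within the scatter). Nothing available explains the step from isopropyl to methylsulfonyl.

Still open, going by these compounds, is where an amine or a carboxylic acid at that carbon would fall relative to compound 2 and compound 3.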